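The source may hold more compounds than are shown below. What is called first, only, known or untested is meant among the compounds shown, and "the series" means these compounds.

Measured in a functional assay on HeLa cells (Homo sapiens) for inhibition, read by MTT assay, with a stated time of 48 h; on this read-out lower numbers stand for stronger inhibition and higher numbers for weaker inhibition:
- compound 1 `O=C(CCCCOc1no[n+]([O-])c1S(=O)(=O)c1ccccc1)NO`: 3650 nM
- compound 2 `O=C(CCCCCCCOc1no[n+]([O-])c1S(=O)(=O)c1ccccc1)NO`: 5030 nM
- compound 3 `O=C(COCCOc1no[n+]([O-])c1S(=O)(=O)c1ccccc1)NO`: 6690 nM

Compound 3 lies within the scatter of both others: a 1.8-fold higher number from compound 1 to compound 3 (0.26 log units; within the scatter), and a 1.3-fold higher number from compound 2 to compound 3 (0.12 log units; within the scatter).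

Next is compound 4 `O=C(NO)OCCOCCOc1no[n+]([O-])c1S(=O)(=O)c1ccccc1`, with this change: ((hydroxycarbamoyl)oxy)methyl in place of hydroxycarbamoyl on a saturated chain carbon bound to an oxygen on a saturated carbon. In words, ((hydroxycarbamoyl)oxy)methyl stands in place of hydroxycarbamoyl on a saturated chain carbon bound to an oxygen on a saturated carbon.

All measured chain changes stayed within the scatter, including a 1.4-fold higher number from compound 1 to compound 2 (0.14 log units; within the scatter). For the measured compounds named here, no measured compound carries the (hydroxycarbamoyl)oxy group, so these steps bear on the chain only and the estimate stays wide. No step beyond the scatter is expected: a 1.1-fold lower number from compound 3 to compound 4 (0.05 log units; within the scatter).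

For compound 4 the estimated value is 6000 nM, with an expected range of 2500 nM to 14000 nM.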

Compound 4, half-maximal inhibitory concentration: 5140 nM
Compound 4: the middle estimate sits 1.2-fold (0.07 log units) above what was measured; low and high end bracket the measured number.
By their numbers in this assay, from the lowest: compounds 1, 2, 4 and 3 (each within the scatter of the next).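

In this assay, ((hydroxycarbamoyl)oxy)methyl in place of hydroxycarbamoyl gives a 1.3-fold lower number from compound 3 to compound 4 (0.11 log units; within the scatter), so this position carries the (hydroxycarbamoyl)oxy group with no step beyond the scatter. The comparisons with the all-carbon chains read the same way, with a 1.0-fold higher number from compound 2 to compound 4 (0.01 log units; within the scatter) and a 1.4-fold higher number from compound 1 to compound 4 (0.15 log units; within the scatter), so the flat picture now extends to this new chain end. No available measurement offers an explanation for this result. Open, as far as these compounds go, is whether a carboxylic acid or an amine at the chain end, or a longer chain, would give a step beyond the scatter.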